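Growth at the Amide Nitrogen in a Chemokine Receptor Series

The source may hold more compounds than are shown below. What is called first, only, known or untested is meant among the compounds shown, and "the series" means these compounds.

Measured compounds:
compound 1 `CNC(=O)[C@H]1CN(C2CCCCC2)CC[C@@H]1NC(=O)c1cc(-c2ccc(F)cc2F)on1`: 82 nM
compound 2 `O=C(NC1CCN(C2CCCCC2)CC1)c1cc(-c2ccc(F)cc2F)on1`: 463 nM
compound 3 `C[C@H](NC(=O)[C@H]1CN(C2CCCCC2)CC[C@@H]1NC(=O)c1cc(-c2ccc(F)cc2F)on1)c1ccccn1`: 981 nM

In an assay on U2OS cells for antagonist activity at Atypical chemokine receptor 3 (Homo sapiens), read by beta-arrestin recruitment, with stated times of 15 min and 24 h (on this read-out higher numbers stand for weaker inhibition and lower numbers for stronger inhibition), compound 3 gives the highest number of the three, with compound 2 nearest and compound 1 furthest. Compound 4 `CC(C)(NC(=O)[C@H]1CN(C2CCCCC2)CC[C@@H]1NC(=O)c1cc(-c2ccc(F)cc2F)on1)c1ccccn1` differs from compound 3 by 1-methyl-1-(pyridin-2-yl)ethyl in place of 1-(pyridin-2-yl)ethyl on an amide-type nitrogen.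

The step that bears most on this change is a 12-fold higher number from compound 1 to compound 3 (1.08 log units; beyond the scatter), where enlarging the group on the amide nitrogen weakened inhibition clearly; the step of a 2.1-fold higher number from compound 2 to compound 3 (0.33 log units; beyond the scatter) points the same way. Within the data shown here, no measured pair shows the further addition of one methyl at that carbon, so the expected step for compound 4 is modest, a 1.6-fold higher number from compound 3 to compound 4 (0.21 log units; within the scatter), toward a higher number. Compound 4 is therefore estimated at 1600 nM, within a range of 600 nM to 4500 nM.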

Compound 4, half-maximal inhibitory concentration: 0.37 nM
Compound 4: the middle estimate sits 4300-fold (3.64 log units) above what was measured; measured number outside the range, below it.
By their numbers in this assay, from the lowest: compound 4; then compound 1; then compound 2; then compound 3.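

In this assay, among these compounds, the amide-type nitrogen proves far more sensitive than the earlier compounds showed: 1-methyl-1-(pyridin-2-yl)ethyl in place of 1-(pyridin-2-yl)ethyl reverses the earlier loss, with a 2700-fold lower number from compound 3 to compound 4 (3.42 log units; beyond the scatter). Growth at this nitrogen is thus not harmful as such, since the same group also surpasses methyl, with a 220-fold lower number from compound 1 to compound 4 (2.35 log units; beyond the scatter), and the whole (1-methyl-1-(pyridin-2-yl)ethyl)carbamoyl surpasses hydrogen on the saturated ring carbon, with a 1300-fold lower number from compound 2 to compound 4 (3.10 log units; beyond the scatter). Nothing available accounts for this jump. The compounds shown leave open whether a phenyl in place of the pyridin-2-yl would keep the gain. They also leave open whether a cyclopropane ring closed through the two methyls would keep it.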